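Solubility notes on furan-to-benzyl swap in compound 1 series

A few compounds are considered here, and "the series" means these few. Any claim that something is new, unique, unknown or untested is made for them only; others in the source may bear on it.

Measured so far:
compound 1 `CC(C)(C)c1ccc(Oc2ccc3c(NCCCNCc4ccco4)ccnc3c2)cc1` — 14500 nM
compound 2 `c1ccc(Oc2ccc3c(NCCCNCc4ccco4)ccnc3c2)cc1` — 14500 nM

In a physicochemical assay for solubility, with a stated time of 18 h, at pH 7.4 (a lower number here means a less soluble compound, a higher number a more soluble compound), compound 1 gives 14500 nM and compound 2 gives 14500 nM; compound 1 stands level with compound 2 within the scatter, the step of no change at the digits printed from compound 1 to compound 2 (within the scatter) being no change. Compound 3 `COc1ccc(F)cc1CNCCCNc1ccnc2cc(Oc3ccc(C(C)(C)C)cc3)ccc12` differs from compound 1 by 5-fluoro-2-methoxyphenyl in place of furan-2-yl on a saturated chain carbon bound to an amine nitrogen. For the measured compounds named here, no measured step touches this part of the molecule; the only step known concerns the tert-butyl group and was flat. The step of a 1.8-fold lower number from compound 1 to compound 3 (0.26 log units; within the scatter) is therefore expected to be small, at most a modest fall. Compound 3 is estimated at 8000 nM, range 3000 nM to 25000 nM.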

Compound 3, solubility: 14500 nM
Compound 3: the middle estimate sits 1.8-fold (0.26 log units) below what was measured, and the stated range covers the measured number.
By their numbers in this assay, from the lowest: compounds 1, 2 and 3 (each within the scatter of the next).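

In this assay, 5-fluoro-2-methoxyphenyl in place of furan-2-yl on a saturated chain carbon bound to an amine nitrogen gives no change at the digits printed from compound 1 to compound 3 (within the scatter). For the compounds shown here, the earlier step covered only the tert-butyl position, so this is the first reading at this end of the molecule, and the larger aromatic group, at 9 heavy atoms against 5, leaves the number flat. No supporting data bear on the reason for this flat result.

Open, going by these compounds, is whether a carboxylic acid on the 5-fluoro-2-methoxyphenyl group, or a longer chain carrying it, would shift the read-out. Also open, on these data alone, is whether the same swap stays flat on compound 2.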